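The source may report more compounds than this note shows. Statements on the series, on what has been measured and on what is new or still open speak of the compounds shown alone.

Compound 3 `Nc1ccccc1NC(=O)c1ccc(CSC(=S)N2CCN(c3ccncc3)CC2)cc1` gives 64.8% in a functional assay on MGC-803 cells (Homo sapiens) for antiproliferative activity, read by CCK-8 assay, with a stated time of 72 h, tested at 2 uM (on this read-out higher numbers stand for a stronger effect at the one concentration tested and lower numbers for a weaker effect), and stands highest of the three numbers measured. Compound 1 `Nc1ccccc1NC(=O)c1ccc(CSC(=S)N2CCN(C3CCCCC3)CC2)cc1` gives 16.9% in this assay, and compound 2 `Nc1ccccc1NC(=O)c1ccc(CSC(=S)N2CCN(C(c3ccccc3)c3ccccc3)CC2)cc1` gives 9.8%. Compound 4 `Nc1ccccc1NC(=O)c1ccc(CSC(=S)N2CCN(Cc3ccccc3)CC2)cc1` has not yet been measured; its structural change from compound 3 is benzyl in place of pyridin-4-yl on an amine nitrogen in a ring. For the measured compounds named here, the one measured step that bears on this position is a number 47.9 percentage points higher from compound 1 to compound 3 (beyond the scatter), which shows how much the group on the ring nitrogen can move the read-out; the pyridin-4-yl group that sets compound 3 apart is the very group that leaves in compound 4. Compound 4 is therefore expected to fall well below compound 3, with an estimated step of a number 44.8 percentage points lower from compound 3 to compound 4 (beyond the scatter). Compound 4 is estimated at 20%, within a range from 5% to 45%.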

Compound 4, a percentage reported as inhibition, at one concentration (the size of the read-out at that concentration, not a potency): 18.1%
Compound 4: the middle estimate sits 1.9 percentage points above what was measured; low and high end bracket the measured number.
By their numbers in this assay, from the lowest: compounds 2, 1 and 4 (each within the scatter of the next); then compound 3.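

In this assay the change to benzyl gives a number 46.7 percentage points lower from compound 3 to compound 4 (beyond the scatter) and so does not keep the level of pyridin-4-yl. Benzyl instead sits with the other groups on this amine nitrogen, with a number 1.2 percentage points higher from compound 1 to compound 4 (within the scatter) and, on losing one phenyl from the group of compound 2, a number 8.3 percentage points higher from compound 2 to compound 4 (within the scatter), so among these four compounds only pyridin-4-yl stands apart. Nothing available gives a reason for this. The compounds shown leave open whether phenyl or pyridin-3-yl on the same nitrogen would reach the level of compound 3, and so whether the hetero atom, its place in the ring or the direct attachment of the ring matters.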